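The compounds below may be only part of what the source reports. "The series", "measured", "known", "first", "only" and "open" are said of these compounds alone.

Among the compounds with values here, in a functional assay on SEM cells (Homo sapiens) for cytotoxicity, with a stated time of 72 h (a lower number here means that less compound is needed, a higher number that more compound is needed for the effect), none of the compounds measured so far has given a number. Compound 1 `C=C[C@@](C)(/C=C/c1ccc(O)cc1)CC/C=C/C#N` reaches only the assay limit of > 36600 nM. Compound 2 `C=C[C@@](C)(/C=C/c1ccc(Nc2ccc(OC)c(OC)c2)cc1)CCC=C(C)C` likewise reaches only the limit of > 36600 nM. Compound 3 `C=C[C@@](C)(/C=C/c1ccc(Nc2ccc(OC)c(F)c2)cc1)CCC=C(C)C` stands at the same place, with a limit of > 36600 nM. For compound 1, compound 2 and compound 3 alike, the record is the limit of > 36600 nM in this assay, at which 3 of the 3 values shown sit.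

The next analogue, compound 4 `C=C[C@@](C)(/C=C/c1ccc(Nc2cc(F)c(F)c(F)c2)cc1)CCC=C(C)C`, carries 3,4,5-trifluorophenyl in place of 3-fluoro-4-methoxyphenyl on a nitrogen on an aromatic ring. The nearest measured change is a step that the two limits leave unreadable from compound 2 to compound 3, where fluoro replaced methoxy on an aromatic carbon, but it gives no size to carry forward. With no readable step to build on, no shift beyond the scatter is expected in this assay, in either direction, and compound 4 will most likely also be reported only as a limit.

The estimated value for compound 4 is 37000 nM, with an expected range from 15000 nM to 80000 nM. The expected change is a step that the limit leaves unreadable from compound 3 to compound 4.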

Compound 4, half-maximal effective concentration: > 36600 nM
Compound 4 gave a limit, no number (the forecaster's own chance of this, stated with the estimate: 75%); the middle value is on the limit's open side.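

Compound 3 and compound 4 are both reported only as limits, so no step can be read between them, and all four compounds stand at the same limit: the limit of > 36600 nM in this assay, at which 4 of the 4 values shown sit.

The compounds shown leave open whether changing the group on the nitrogen alters the effect in this assay at all.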